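Chalcone thiazole series: dichlorophenyl replacing tolyl on the amine

The source may hold more compounds than are shown below. What is called first, only, known or untested is meant among the compounds shown, and "the series" means these compounds.

Working notes on the aryl-amino chalcone thiazoles. In a functional assay on PC-3 cells (Homo sapiens) for cytotoxicity, read by MTT assay (a lower number here means a stronger inhibitor, a higher number a weaker inhibitor), compound 1 `COc1cccc(/C=C/C(=O)c2sc(Nc3ccc(Cl)cc3)nc2C)c1` gives only a limit, > 25000 nM. Compound 2 `Cc1ccc(Nc2nc(C)c(C(=O)/C=C/c3ccc(Cl)cc3)s2)cc1` likewise gives only a limit in this assay, > 25000 nM. Both values shown sit at the limit of > 25000 nM in this assay, at which 2 of the 2 values shown sit, so no step between measured compounds can be stated, and compound 2 stands nowhere in particular within the shown numbers: it is simply inactive up to the limit.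

Compound 3 `Cc1nc(Nc2ccc(Cl)c(Cl)c2)sc1C(=O)/C=C/c1ccc(Cl)cc1` differs from compound 2 by 3,4-dichlorophenyl in place of 4-methylphenyl on a nitrogen on an aromatic ring. Within the data shown here, no measured step informs this change, so the expected step from compound 2 to compound 3 in this assay is none beyond the scatter, with a modest chance of a gain; the estimated a number no higher from compound 2 to compound 3 (the limit leaves the size open) reflects that. Compound 3 is therefore estimated at 25000 nM in this assay, with a range from 8000 nM to 80000 nM, most likely again reported only as a limit.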

Compound 3, half-maximal inhibitory concentration: > 25000 nM
Compound 3: no number, only a limit; the forecaster's own chance of this, stated with the estimate: 70%; the middle value sits exactly at the limit.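

No step from compound 2 to compound 3 can be read in this assay, because both give only a limit: the limit of > 25000 nM in this assay, at which 3 of the 3 values shown sit.

The compounds shown leave open what 3,4-dichlorophenyl in place of 4-methylphenyl does to potency, and whether any member of the series reads as a number in this assay.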